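Methylphenyl position on the piperazine: from compound 1 to compound 3

A few compounds are considered here, and "the series" means these few. Any claim that something is new, unique, unknown or untested is made for them only; others in the source may bear on it.

Compound 1 `CCCc1nc(-c2ccccc2)c(CNCCN2CCN(c3cccc(C)c3)CC2)o1` has the lower of the two measured numbers: in an assay on HEK293 cells for inhibition of Voltage-dependent T-type calcium channel subunit alpha-1G (Homo sapiens), read by fluorescence, tested at 10 uM (on this read-out lower numbers stand for less inhibition and higher numbers for more inhibition at the one concentration tested (going by the name of the read-out)), compound 1 gives 43.1%, while compound 2 `CCCc1nc(-c2ccccc2)c(CNCCCN2CCN(c3ccc(F)cc3)CC2)o1` gives 62.5% in this assay, a gap beyond the scatter. The next step keeps compound 1 and moves only the methyl on the aryl ring: compound 3 `CCCc1nc(-c2ccccc2)c(CNCCN2CCN(c3ccccc3C)CC2)o1` differs by 2-methylphenyl in place of 3-methylphenyl on an amine nitrogen in a ring. Within the data shown here, no measured pair shows this kind of change, so the expected step in this assay is small, with no clear direction and likely within the scatter. Compound 3 is therefore estimated at 40% in this assay, within 20% to 60%, a step of a number 3.1 percentage points lower from compound 1 to compound 3 (within the scatter) expected from compound 1.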

Compound 3, a percentage reported as inhibition, at one concentration (the size of the read-out at that concentration, not a potency): 51.3%
Beside the measured number, compound 3's estimate is 11.3 percentage points below it; low and high end bracket the measured number.
By their numbers in this assay, from the lowest: compounds 1 and 3 (each within the scatter of the next); then compound 2.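

Swapping 3-methylphenyl for 2-methylphenyl on the amine nitrogen in a ring gives the first pair in the series that differs in one place, and in this assay it reads as a number 8.2 percentage points higher from compound 1 to compound 3 (within the scatter) and so does not separate the two methylphenyl groups. No measurement shown offers an explanation for this result.

Compound 2 differs from compound 1 in more than one place, so its value cannot be assigned to either its chain or its fluorophenyl group. On these data alone, how an unsubstituted phenyl or a methoxyphenyl on this nitrogen would read remains open.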